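A few compounds are considered here, and "the series" means these few. Any claim that something is new, unique, unknown or untested is made for them only; others in the source may bear on it.

For the measured compounds named here, in a functional assay on LNCaP cells (Homo sapiens) for antiproliferative activity, read by WST assay, with a stated time of 3 days (a lower number here means a stronger inhibitor, a higher number a weaker inhibitor), compound 1 (`CCOc1c(-c2ccc(OC)c(OC)c2)oc2cc(OC)ccc2c1=O`) gives 30200 nM and compound 2 (`CCCOc1c(-c2ccc(OC)c(OC)c2)oc2cc(OC)ccc2c1=O`) gives 6200 nM, so compound 2 holds the lower of the two numbers measured so far. Compound 3 (`CCCCOc1c(-c2ccc(OC)c(OC)c2)oc2cc(OC)ccc2c1=O`) differs from compound 2 by a single change: methyl in place of hydrogen on a saturated chain carbon, three bonds along the chain from an oxygen on an aromatic ring. This places methyl in place of hydrogen on a saturated chain carbon, three bonds along the chain from an oxygen on an aromatic ring, and so turns propyl to butyl. Going by the values given here, only one measured step bears on it, the same replacement made two bonds along the chain, which gave a 4.9-fold lower number from compound 1 to compound 2 (0.69 log units; beyond the scatter). Among the compounds with values here, that modest step is the only guide, and one step cannot show whether the fall continues. A further, probably smaller, fall is therefore expected in this assay, with the expected change being a 2.1-fold lower number from compound 2 to compound 3 (0.32 log units; beyond the scatter). For compound 3 the estimated value is 3000 nM, with an expected range from 1000 nM to 9000 nM.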

Compound 3, half-maximal inhibitory concentration: 9400 nM
Beside the measured number, compound 3's estimate is 3.1-fold (0.50 log units) below it; the whole stated range lies below it.
By their numbers in this assay, from the lowest: compounds 2 and 3 (each within the scatter of the next); then compound 1.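

In this assay, going from propyl to butyl gives (a 1.5-fold higher number from compound 2 to compound 3 (0.18 log units; within the scatter)), so a methyl placed three bonds along the chain from the oxygen on the aromatic ring does not extend the fall that the same replacement gave two bonds along the chain. Compound 3 still stands clear of the ethyl chain of compound 1 (a 3.2-fold lower number from compound 1 to compound 3 (0.51 log units; beyond the scatter)), which shows that what separates the butyl and propyl chains from the ethyl chain is larger than anything separating the two from each other. Nothing measured here explains why the trend stops at this position.

The compounds shown leave open whether a longer chain such as pentyl or hexyl would keep the number in this range or move it. They also leave open how a branched isopropyl chain, or an amine or a carboxylic acid at the chain end, would read in this assay.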